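The source may hold more compounds than are shown below. What is called first, only, known or untested is meant among the compounds shown, and "the series" means these compounds.

Measured so far:
- compound 1 `c1ccc(NC2=NCCC3(CCCCC3)S2)cc1`: in a functional assay on a subcellular fraction from brain (Rattus norvegicus) for inhibition, read by scintillation counting, with a stated time of 5 min (on this read-out lower numbers stand for stronger inhibition and higher numbers for weaker inhibition), compound 1 gives 63100 nM
- compound 2 `CCc1cccc(CC)c1NC1=NCCC2(CCCCC2)S1`: in this assay compound 2 gives 7900 nM

Compound 1 stands highest of the two numbers; compound 2 shows a lower number, and the gap lies beyond the usual scatter. Compound 3 `FC(F)(F)c1ccc(NC2=NCCC3(CCCCC3)S2)cc1` is not yet measured. It differs from compound 1 by trifluoromethyl in place of hydrogen on an aromatic carbon of a six-membered aromatic ring of carbon only, para to a large group. Among the measured compounds shown here, no measured pair isolates this change, so the direction rests on weak footing. A small move toward a lower number is expected, a 2.1-fold lower number from compound 1 to compound 3 (0.32 log units; beyond the scatter). For compound 3 the estimate is 30000 nM, within a range of 8000 nM to 100000 nM.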

Compound 3, half-maximal inhibitory concentration: 77600 nM
The estimate for compound 3 lay 2.6-fold (0.41 log units) below the measured number, and the stated range covers the measured number.
By their numbers in this assay, from the lowest: compound 2; then compounds 1 and 3 (each within the scatter of the next).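

In this assay, trifluoromethyl in place of hydrogen on an aromatic carbon, para to a large group, gives a 1.2-fold higher number from compound 1 to compound 3 (0.09 log units; within the scatter). On this read-out compound 1 and compound 3 cannot be told apart, so this position accepts trifluoromethyl with no change beyond the scatter. Nothing at hand bears on why this is so. Going by these compounds, whether an amine, a carboxylic acid or a methoxy group at this place would also leave the number unchanged remains open. On these data alone, the effect of trifluoromethyl on another carbon of this ring also remains open.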